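Cytotoxicity notes: trimming the isopropylamino group of compound 2

A few compounds are considered here, and "the series" means these few. Any claim that something is new, unique, unknown or untested is made for them only; others in the source may bear on it.

Compound 2 `CC(C)Nc1nc(Nc2ccc(C#N)cc2)nc(Oc2ccc3ccccc3c2Br)n1` is the reference point for the next compound in this series. In an ADME assay on MT4 cells (Homo sapiens) for cytotoxicity, read by MTT assay, with a stated time of 4 days (a lower number here means that less compound is tolerated, a higher number that more compound is tolerated), compound 2 gives 41500 nM, the lowest of the two numbers shown. The nearest number belongs to compound 3 `CNc1nc(Nc2ccc(C#N)cc2)nc(Oc2ccc3cc(Br)ccc3c2)n1`, which in this assay gives 194000 nM. Compound 1 `CC(C)Nc1nc(Nc2ccc(C#N)cc2)nc(Oc2ccc3cc(Br)ccc3c2Br)n1` sits at the limit of >= 209000 nM in this assay, at which 1 of the 3 values shown sits; in this assay compound 1 gives >= 209000 nM, a limit of the assay and not a number. Going by the values given here, the single step measured in one place, an at least 5.0-fold lower number from compound 1 to compound 2 (0.70 log units; beyond the scatter), concerns a bromo group on an aromatic carbon and does not touch the amine side chain.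

Compound 4 `N#Cc1ccc(Nc2nc(N)nc(Oc3ccc4ccccc4c3Br)n2)cc1` differs from compound 2 by hydrogen in place of isopropyl on a nitrogen on an aromatic ring. Among the compounds with values here, no measured step alters this nitrogen alone; compounds 1 and 3 differ there but also in a bromo group, so their two values cannot be split between the two changes. With nothing pointing either way beyond the scatter, compound 4 is expected to show a 1.4-fold higher number from compound 2 to compound 4 (0.16 log units; within the scatter), no more than a small shift toward a higher number. The estimate for compound 4 in this assay is 60000 nM, between 20000 nM and 200000 nM.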

Compound 4, half-maximal cytotoxic concentration: 133000 nM
Compound 4: middle estimate off by 2.2-fold (0.35 log units), on the low side; the measured number falls inside the stated range.
By their numbers in this assay, from the lowest: compound 2; then compounds 4 and 3 (each within the scatter of the next). At a limit, above all of these: compound 1.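

In this assay, the amine side chain now has a single-place step of its own: a 3.2-fold higher number from compound 2 to compound 4 (0.51 log units; beyond the scatter), a shift beyond the scatter toward more compound tolerated. Until now, only a bromo group had been read in one place, so this nitrogen is a second site where one change moves the number beyond the scatter, though only compound 2 and compound 4 show it. Nothing measured here gives a cause for this step.

From the compounds shown here alone, this step is read on a single bromo pattern, so whether isopropylamino to amino does the same in the presence of the second bromo group of compound 1 stays open. An ethylamino group or a longer chain such as butylamino on this nitrogen would show whether the number follows chain length or simply separates isopropylamino from amino.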